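This account rests on a few compounds, and the source may have more. Where it says the series, first, only, none or still open, it means among the compounds named here.

Compound 1 `CCn1c(=O)c2nc(-c3ccc(S(=O)(=O)N4CCSCC4)cc3)[nH]c2n(CC)c1=O` carries the shared core with a thiomorpholin-4-yl group on the sulfonyl sulfur and gives 646 nM in an assay for binding affinity to adenosine receptor A1 (Rattus norvegicus), read by radioligand binding; on this read-out higher numbers stand for weaker inhibition and lower numbers for stronger inhibition. Compound 2 `CCn1c(=O)c2nc(-c3ccc(S(=O)(=O)NCCCN(C)C)cc3)[nH]c2n(CC)c1=O` gives 70 nM in this assay, and compound 3 `CCn1c(=O)c2nc(-c3ccc(S(=O)(=O)NCCN(C)C)cc3)[nH]c2n(CC)c1=O` gives 116 nM. Among these three numbers compound 3 is separated from compound 1 by a gap beyond the scatter, while compound 2 and compound 3 cannot be told apart, since a 1.7-fold higher number from compound 2 to compound 3 (0.22 log units; within the scatter). Both open-chain sulfonamides stand clear of the thiomorpholine: a 9.2-fold lower number from compound 1 to compound 2 (0.97 log units; beyond the scatter), and a 5.6-fold lower number from compound 1 to compound 3 (0.75 log units; beyond the scatter).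

Compound 4 `CCn1c(=O)c2nc(-c3ccc(S(=O)(=O)NCC(C)O)cc3)[nH]c2n(CC)c1=O` has not yet been measured in this assay. It differs from compound 3 in one place: 1-hydroxyethyl in place of (dimethylamino)methyl on a saturated chain carbon bound to a sulfonamide nitrogen. Among the compounds with values here, no measured step exchanges a dimethylamino group end for a hydroxyl, so the only guides are the two modest steps out of compound 1, in which the chains ending in a dimethylamino group gave the lower numbers. Taking the dimethylamino group away in compound 4 is therefore expected to move the number part of the way back toward that of compound 1, by an estimated 3.0-fold higher number from compound 3 to compound 4 (0.48 log units; beyond the scatter). Compound 4 is thus expected to give about 350 nM in this assay, within a range from 120 nM to 1000 nM.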

Compound 4, half-maximal inhibitory concentration: 138 nM
Beside the measured number, compound 4's estimate is 2.5-fold (0.40 log units) above it; low and high end bracket the measured number.
By their numbers in this assay, from the lowest: compounds 2, 3 and 4 (each within the scatter of the next); then compound 1.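

In this assay the exchange of (dimethylamino)methyl for 1-hydroxyethyl on a saturated chain carbon bound to a sulfonamide nitrogen stays within the scatter (a 1.2-fold higher number from compound 3 to compound 4 (0.08 log units; within the scatter)), and the comparison with the 2-(dimethylamino)ethyl group of compound 2 does too (a 2.0-fold higher number from compound 2 to compound 4 (0.29 log units; within the scatter)), so among compounds 2, 3 and 4 a number in this range does not depend on a dimethylamino end. The gap to the thiomorpholine remains beyond the scatter with that amine gone (a 4.7-fold lower number from compound 1 to compound 4 (0.67 log units; beyond the scatter)), which shows that the separation of the open-chain sulfonamides from compound 1 is not confined to chains ending in a dimethylamino group. Nothing given here explains why the chain ending in a hydroxyl-bearing carbon and the chains ending in a dimethylamino group cannot be told apart.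

The compounds shown leave open how a 2-hydroxyethyl chain, a methoxy end or a carboxylic acid end would stand on the same sulfonamide nitrogen. They also leave open whether a plain propyl chain, with neither an amine nor a hydroxyl, would stay clear of compound 1.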